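Methoxy in place of hydrogen: compound 1 to compound 3

The source may hold more compounds than are shown below. What is called first, only, known or untested is meant among the compounds shown, and "the series" means these compounds.

Measured compounds:
- compound 1, `Cc1nc(SCC(=O)Nc2nc(-c3ccc(Cl)cc3)cs2)n(Nc2ccccc2)c1C`, gives 38900 nM in a functional assay on OVCAR-8 cells (Homo sapiens) for antiproliferative activity, read by sulforhodamine B assay, with a stated time of 48 h; on this read-out lower numbers stand for higher toxicity in this test and higher numbers for lower toxicity in this test.
- compound 2, `Cc1ccc(Nn2c(SCC(=O)Nc3nc(-c4ccccc4)cs3)nc(C)c2C)cc1`, reaches only the limit of > 100000 nM in this assay.

For the measured compounds named here, compound 1 stands as the only numerical value in this assay; the second value shown is a limit and not a number, namely (the limit of > 100000 nM in this assay, at which 1 of the 2 values shown sits). Compound 3, `COc1ccc(Nn2c(SCC(=O)Nc3nc(-c4ccc(Cl)cc4)cs3)nc(C)c2C)cc1`, is not yet measured. It differs from compound 1 by methoxy in place of hydrogen on an aromatic carbon. Going by the values given here, no step between measured compounds that differ in one place is available, so the expected size of the step rests on compound 1 alone. The expected step from compound 1 to compound 3 in this assay is a 1.5-fold higher number from compound 1 to compound 3 (0.19 log units; within the scatter), a weakening that may not exceed the scatter. The estimate for compound 3 is 60000 nM, with a range from 25000 nM to 150000 nM, and a real chance that only a limit is reported.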

Compound 3, concentration lethal to 50% of the cells: > 100000 nM
Compound 3: no number, only a limit; the forecaster's own chance of this, stated with the estimate: 35%; at least 1.6-fold (0.22 log units) between middle value and limit.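

On the anilino ring, going from phenyl to 4-methoxyphenyl, with methoxy para to a large group, gives an at least 2.5-fold higher number from compound 1 to compound 3 (0.41 log units; beyond the scatter) in this assay. For the compounds shown here, this is the first single-place comparison, and it shows that this position responds to substitution, with the step lying beyond the scatter and toward lower toxicity in this test. Compound 3 gives > 100000 nM, which is a limit and not a number, and the series now rests mostly on such limits: the limit of > 100000 nM in this assay, at which 2 of the 3 values shown sit.

On these data alone, the full size of the step stays open, and this single pair cannot separate the effect of methoxy from that of substitution at this position in general. As far as these compounds go, whether fluoro, hydroxy or an amine at the same carbon would stay close to compound 1 also remains open.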